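The source may report more compounds than this note shows. Statements on the series, on what has been measured and on what is new or still open speak of the compounds shown alone.

Compound 1, `Cc1cccc2cc(S(=O)(=O)NC(=O)Nc3ccc(Cl)cc3)oc12`: 21%
Compound 2, `Cc1cc(S(=O)(=O)NC(=O)Nc2ccc(Cl)cc2)cc2ccoc12`: 89%
Compound 3, `Cc1coc2ccc(S(=O)(=O)NC(=O)Nc3ccc(Cl)cc3)cc12`: 44%

The three measured compounds share a sulfonylurea linked to a chlorophenyl group and a fused bicyclic core, and all were tested in a functional assay on the whole organism (Mus musculus) for inhibition, at a dose of 150 mg/kg by the oral route; a higher number here means more inhibition at the dose given (going by the name of the read-out), a lower number less inhibition. Compound 1 stands lowest of the three: compound 3 lies beyond the scatter above it, and compound 2 lies further still above it, also beyond the scatter. Going by the values given here, none of these pairs differs in only one place, so the numbers show only that the number for compound 1 is the lowest of the three, not which part of the structure accounts for that.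

Compound 4, `O=C(Nc1ccc(Cl)cc1)NS(=O)(=O)c1cc2ccccc2o1`, has not yet been measured in this assay. It differs from compound 1 in one place: hydrogen in place of methyl on an aromatic carbon. Among the compounds with values here, no measured pair shows what the loss of a methyl at this position does, so the expected step is uncertain; the author expects at most a modest change, within or a little beyond the scatter, in either direction.

On that basis, the author expects compound 4 to give 28% in this assay, with a range from 5% to 60%, which means an expected step of a number 7 percentage points higher from compound 1 to compound 4 (within the scatter).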

Compound 4, a percentage reported as inhibition, in the whole organism at one dose (the size of the read-out at that dose, not a potency): 84%
For compound 4 the middle estimate is 56 percentage points below the measured one; the whole stated range lies below it.
By their numbers in this assay, from the lowest: compound 1; then compound 3; then compounds 4 and 2 (each within the scatter of the next).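

Going by these compounds alone, the first pair that differs in one place shows that this position is far from indifferent in this assay: hydrogen in place of methyl gives a number 63 percentage points higher from compound 1 to compound 4 (beyond the scatter), a large step beyond the scatter. Within the data shown here, the change involves only one heavy atom, a single carbon, on an aromatic carbon of the six-membered ring, ortho to a fused ring and meta to a fused ring, so the low number of compound 1 can now be tied to this methyl, at least on this core, which the earlier compounds could not do. The data shown offer no measurement that explains why this one methyl carries so large a step.

The compounds shown leave open how other groups on this same carbon would read out, for instance whether a chlorine atom, a methoxy group or an ethyl chain would stay close to the methyl of compound 1 or to the hydrogen of compound 4. They also leave open whether removing a methyl has a step of this size on the cores of compound 2 and compound 3, where the methyl sits elsewhere.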